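The source may hold more compounds than are shown below. What is called first, only, known or untested is meant among the compounds shown, and "the series" means these compounds.

Compound 2 `Cc1cc(C)c(-c2ncc[nH]2)cc1NC(=O)c1ccc(OCc2ccccn2)cc1` is one of three measured analogues that share a core. In a physicochemical assay for lipophilicity (on this read-out higher numbers stand for higher lipophilicity and lower numbers for lower lipophilicity), compound 2 gives 3.1, the highest of the three numbers, though its neighbours sit within the scatter: compound 3 `Cc1cc(F)c(-c2ncc[nH]2)cc1NC(=O)c1ccc(OCc2ccccn2)cc1` gives 3, and compound 1 `Cc1ccc(-c2nccn2C)cc1NC(=O)c1ccc(OCc2ccccn2)cc1` gives 2.8. Among the compounds with values here, the only single-point step among the measured compounds is a number 0.10 log units lower from compound 2 to compound 3 (within the scatter), which concerns a change at a different position and does not touch the five-membered ring. Compound 1 and compound 2 differ in two places at once, so their values can be compared only as two numbers, and they lie within the scatter of each other.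

Compound 4 `Cc1cc(C)c(-c2ccccn2)cc1NC(=O)c1ccc(OCc2ccccn2)cc1` differs from compound 2 in one place: pyridin-2-yl in place of 1H-imidazol-2-yl on an aromatic carbon. Within the data shown here, no measured step bears on this exchange, so the expectation rests on the counted difference alone, in which a hydrogen-bond donor leaves and one more heavy atom enters. For compound 4 the estimate in this assay is therefore 4, within a range of 3.5 to 4.5. This estimate means a step of a number 0.90 log units higher from compound 2 to compound 4 (beyond the scatter), expected to lie beyond the scatter, upward.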

Compound 4, distribution coefficient: > 3
Compound 4 ended at the assay's limit (the forecaster's own chance of this, stated with the estimate: 5%); the middle value is on the limit's open side.
By their numbers in this assay, from the lowest: compounds 1, 3 and 2 (each within the scatter of the next).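

In this assay, within the data shown here, compound 4 gives > 3, which is a limit of the assay and not a number, so no step from compound 2 to compound 4 can be read: the limit of > 3 in this assay, at which 1 of the 4 values shown sits. The compounds shown leave open how far pyridin-2-yl in place of 1H-imidazol-2-yl moves the number in this assay, and whether that step lies beyond the scatter.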